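From sec-butyl to isobutyl on an amine nitrogen

The source may report more compounds than this note shows. Statements on the series, on what has been measured and on what is new or still open speak of the compounds shown alone.

Compound 1 `CCC(C)NC(=C\C(=O)/C=C/c1ccc(O)c(OC)c1)/C=C/c1ccc(O)c(OC)c1`: > 25000 nM
Compound 2 `COc1cc(/C=C/C(=O)CC(=O)/C=C/c2ccc(OC(C)=O)c(OC)c2)ccc1OC(C)=O`: > 25000 nM

Both entries come from a functional assay on CHO-K1 cells (Cricetulus griseus) for inhibition, read by sulforhodamine B assay, with a stated time of 72 h; a higher number here means a weaker inhibitor, a lower number a stronger inhibitor. Compound 1 gives > 25000 nM, which is a limit and not a number. Compound 2 gives > 25000 nM, which is likewise a limit. Compound 1 therefore stands at the limit of > 25000 nM in this assay, at which 2 of the 2 values shown sit, so the data show no measured potency for it.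

The next compound is compound 3 `COc1cc(/C=C/C(=O)/C=C(/C=C/c2ccc(O)c(OC)c2)NCC(C)C)ccc1O`, which carries isobutyl in place of sec-butyl on an amine nitrogen. Among the measured compounds shown here, no measured step between related compounds is available to gauge such a change. In this assay, the expectation is therefore for no shift beyond the scatter, in either direction. This expectation rests on compound 1, which shows only > 25000 nM, and the change leaves the counted atoms the same. The expected change is a number no higher from compound 1 to compound 3 (the limit leaves the size open). Compound 3 may well reach the same limit rather than give a number. For compound 3 the estimated value is 25000 nM, with an expected range of 10000 nM to 60000 nM.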

Compound 3, half-maximal inhibitory concentration: > 25000 nM
Compound 3: a limit, no number (the forecaster's own chance of this, stated with the estimate: 70%); the middle value lies on the limit itself.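

In this assay compound 3 gives > 25000 nM, which is a limit and not a number. Compound 1 also stands at a limit, so the step from sec-butyl to isobutyl between compound 1 and compound 3 cannot be read. The compounds shown leave open whether any of them has a measurable potency in this assay.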